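A few compounds are considered here, and "the series" means these few. Any claim that something is new, unique, unknown or untested is made for them only; others in the source may bear on it.

Compound 1 `Cc1ccc2nc(Nc3nc(Nc4ccc(S(N)(=O)=O)cc4)ncc3F)sc2c1` and compound 2 `NS(=O)(=O)c1ccc(Nc2ncc(F)c(Nc3nc4ccccc4s3)n2)cc1` share one core, and in a functional assay on HCT-116 cells (Homo sapiens) for antiproliferative activity, read by MTT assay, with a stated time of 48 h (a higher number here means a weaker inhibitor, a lower number a stronger inhibitor), compound 1 gives 1460 nM while compound 2 gives 3260 nM. The change methyl in place of hydrogen on an aromatic carbon made a step of a 2.2-fold lower number from compound 2 to compound 1 (0.35 log units; beyond the scatter). Compound 3 `CS(=O)(=O)c1ccc(Nc2nccc(Nc3nc4ccc(F)cc4s3)n2)cc1` has a different core; how its core differs from that of compound 2 is not broken down here. In this assay compound 3 gives 860 nM, the lowest of the three numbers. Compound 4 `Cc1cnc(Nc2ccc(S(C)(=O)=O)cc2)nc1Nc1nc2ccc(F)cc2s1` is not yet measured and carries the change (methyl in place of hydrogen on an aromatic carbon). This is the same kind of change as before, yet the place differs: earlier the methyl entered a six-membered aromatic ring of carbon only, part of a fused or bridged system of two rings; here it enters a six-membered aromatic ring with 2 nitrogen, ortho to a large group and para to a large group. Because the earlier step of a 2.2-fold lower number from compound 2 to compound 1 (0.35 log units; beyond the scatter) was modest, a similar or smaller step is expected from compound 3, namely a 1.6-fold lower number from compound 3 to compound 4 (0.19 log units; within the scatter). Compound 4 is therefore estimated at 550 nM, within a range from 180 nM to 1700 nM.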

Compound 4, half-maximal inhibitory concentration: 24000 nM
For compound 4 the middle estimate is 44-fold (1.64 log units) below the measured one; the whole stated range lies below it.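

In this assay, a methyl in place of hydrogen on an aromatic carbon of the six-membered aromatic ring with 2 nitrogen gave a 28-fold higher number from compound 3 to compound 4 (1.45 log units; beyond the scatter) and so the change did not carry over between the two cores, in size or in direction: the same change on two cores in this assay, a 2.2-fold lower number (0.35 log units; beyond the scatter) from compound 2 to compound 1 and a 28-fold higher number (1.45 log units; beyond the scatter) from compound 3 to compound 4, 62-fold (1.79 log units) apart, beyond the scatter of two such steps.
The two methyls differ in both core and ring, and one pair for each cannot tell which of these matters. Nor does this show why the number rose so sharply, or that the result extends beyond these four compounds.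

On these data alone, whether a chlorine, a methoxy or an amine on that same carbon would follow the methyl remains open. So does whether an ethyl would give a step of similar size.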